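Swapping sec-Butyl for 3-Hydroxypropyl: Cytotoxicity Outlook

The source may report more compounds than this note shows. Statements on the series, on what has been measured and on what is new or still open speak of the compounds shown alone.

Compound 2, `CCC(C)Nc1cc(Oc2c(OC)cc3cc(C#N)ccc3c2OC)nc(Nc2ccc(C#N)cc2)n1`, is tolerated up to the ceiling of an ADME assay on MT4 cells (Homo sapiens) for cytotoxicity, read by MTT assay, with a stated time of 5 days; a lower number here means that less compound is tolerated, a higher number that more compound is tolerated: compound 2 gives only the assay's limit of > 125000 nM. Compound 1, `COc1cc2cc(C#N)ccc2c(OC)c1Oc1cc(NCC(C)C)nc(Nc2ccc(C#N)cc2)n1`, likewise reaches only a limit in this assay, > 125000 nM. The step that the two limits leave unreadable from compound 1 to compound 2 cannot be sized because of the limit of > 125000 nM in this assay, at which 2 of the 2 values shown sit. Compound 3, `COc1cc2cc(C#N)ccc2c(OC)c1Oc1cc(NCCCO)nc(Nc2ccc(C#N)cc2)n1`, differs from compound 2 by 3-hydroxypropyl in place of sec-butyl on a nitrogen on an aromatic ring. Going by the values given here, no measured step reads on this change, and both known values sit at the limit, so no shift beyond the scatter is expected. Compound 3 is estimated to give 125000 nM in this assay, between 50000 nM and 400000 nM. The step of a number no higher from compound 2 to compound 3 (the limit leaves the size open) is expected to be negligible.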

Compound 3, half-maximal cytotoxic concentration: 23500 nM
Estimate against measurement, compound 3: 5.3-fold (0.73 log units) above; measured number below the stated range.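

In this assay, the group on this nitrogen turns out to matter: 3-hydroxypropyl in place of sec-butyl gives an at least 5.3-fold lower number from compound 2 to compound 3 (0.72 log units; beyond the scatter). The comparison with the isobutyl compound points the same way, with an at least 5.3-fold lower number from compound 1 to compound 3 (0.72 log units; beyond the scatter), so cells tolerate less of the hydroxyl-bearing compound than of either compound with a branched chain. Both steps are minimum sizes because the two branched compounds reach only a limit: the limit of > 125000 nM in this assay, at which 2 of the 3 values shown sit.

From the compounds shown here alone, whether the hydroxyl or the unbranched chain goes with the lower number remains open. A plain propyl chain would separate the two, and a terminal amine would show whether another end group behaves alike.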